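Ring Expansion on the Amine Substituent of Compound 1

The source may report more compounds than this note shows. Statements on the series, on what has been measured and on what is new or still open speak of the compounds shown alone.

Compound 1 `Cc1nn([C@H](C)c2ccc(Cl)cc2Cl)c2nc(N3CC[C@H](N4CCCCC4)[C@H](C)C3)cnc12`: 361 nM
Compound 2 `C[C@@H]1CC(c2cnc3c(C#N)nn([C@H](C)c4ccc(Cl)cc4Cl)c3n2)=CC[C@@H]1N1CCC[C@H]1C`: 44 nM
Compound 3 `C[C@@H]1CC(c2cnc3c(C#N)nn([C@H](C)c4ccc(Cl)cc4Cl)c3n2)=CC[C@@H]1N1CCC[C@H]1C(N)=O`: 1380 nM

Of the compounds shown here, three have been measured in an assay on CCRF-CEM cells for antagonist activity at C-C chemokine receptor type 4 (Homo sapiens), read by CellTiter-Glo, with stated times of 30 min and 60 min, in the presence of a further agent that is not named here; on this read-out higher numbers stand for weaker inhibition and lower numbers for stronger inhibition. Compound 1 gives 361 nM, the second highest of the three numbers. Compound 2 gives 44 nM, a lower number than compound 1, while compound 3 gives 1380 nM, a higher number than compound 1. Going by the values given here, the only step between two compounds that differ in one place is a 31-fold higher number from compound 2 to compound 3 (1.50 log units; beyond the scatter); it concerns a change on a different scaffold from compound 1.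

Compound 4 `Cc1nn([C@H](C)c2ccc(Cl)cc2Cl)c2nc(N3CC[C@H](N4CCCCCC4)[C@H](C)C3)cnc12` has not yet been measured. It differs from compound 1 in one place: azepan-1-yl in place of piperidin-1-yl on a saturated ring carbon. No measured pair shows what swapping one saturated nitrogen ring for a larger one does in this assay, and the single step shown, from compound 2 to compound 3, tells nothing about this change. Among the compounds with values here, with no guiding step, the expectation is a number close to that of compound 1, within the usual scatter, in either direction.

Compound 4 is therefore expected to give about 360 nM in this assay, with a range from 120 nM to 1100 nM. The expected step from compound 1 to compound 4 is a 1.0-fold lower number from compound 1 to compound 4 (0.00 log units; within the scatter), which is no step beyond the scatter.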

Compound 4, half-maximal inhibitory concentration: 195 nM
Compound 4: the middle estimate sits 1.8-fold (0.27 log units) above what was measured; measured number inside the range.
By their numbers in this assay, from the lowest: compound 2; then compounds 4 and 1 (each within the scatter of the next); then compound 3.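

On the saturated ring carbon three ring bonds from the ring nitrogen, azepan-1-yl in place of piperidin-1-yl gives a 1.9-fold lower number from compound 1 to compound 4 (0.27 log units; within the scatter) in this assay, so this read-out does not separate the two compounds. Going by these compounds alone, this is the first pair on the core of compound 1 that differ in one place, and it shows that a seven-membered ring can stand on this carbon in place of a six-membered one with no step beyond the scatter. The two groups have the same counts of hydrogen-bond donors and acceptors and no net charge, and no measurement at hand explains the result or tells what the added ring carbon does.

As far as these compounds go, only these two ring sizes are compared at this position, so it remains open whether the same holds for an open-chain amine such as dimethylamino or for a ring with a second hetero atom such as morpholin-4-yl. It also remains open whether azepan-1-yl would behave the same way on the core of compound 2, where the single step shown concerns a different change.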